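The source may hold more compounds than are shown below. What is called first, only, known or untested is meant among the compounds shown, and "the series" means these compounds.

Measured so far in an ADME assay for permeability, using PAMPA, with a stated time of 4 h, at pH 5.5; a lower number here means that the compound crosses the layer more slowly, a higher number that the compound crosses the layer faster
Compound 1 `CN(C[C@@H]1Cc2ncccc2CN1)[C@H]1CCCc2cccnc21` with 230 nm/s
Compound 2 `NC/C=C\CN(C[C@H]1Cc2ncccc2CN1)[C@H]1CCCc2cccnc21` with 28 nm/s

In this assay compound 2 stands lowest of the two at 28 nm/s and compound 1 lies higher at 230 nm/s by a gap beyond the scatter. Compound 3 `NC(=O)NC/C=C\CN(C[C@H]1Cc2ncccc2CN1)[C@H]1CCCc2cccnc21` is compound 2 with carbamoyl in place of hydrogen on an amine nitrogen and so turns amino to ureido. Within the data shown here, no two measured compounds differ in one place only, so the data offer no direct guide to this change. A modest upward step is nevertheless expected in this assay for this change, as compound 1 at 230 nm/s shows that higher numbers occur with this core. The expected change is a 1.4-fold higher number from compound 2 to compound 3 (0.13 log units; within the scatter) and it may well stay within the scatter. For compound 3 the estimated value is 38 nm/s with an expected range from 11 nm/s to 130 nm/s in repeated measurements.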

Compound 3, apparent permeability: 5 nm/s
Beside the measured number, compound 3's estimate is 7.6-fold (0.88 log units) above it; measured number below the stated range.
By their numbers in this assay, from the lowest: compound 3; then compound 2; then compound 1.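

Carbamoyl in place of hydrogen on this amine nitrogen, which turns amino to ureido, gives a 5.6-fold lower number from compound 2 to compound 3 (0.75 log units; beyond the scatter) in this assay and is the first change in one place that can be read in this set. The earlier compounds shown here offered no such direct reading, and this step shows that the number in this assay is not indifferent to what is carried on this nitrogen. Nothing available explains the drop, so its origin remains unknown.

This single step cannot show whether the fall belongs to carbamoyl alone or would also follow other replacements of hydrogen on this nitrogen, such as an acetyl group, a methyl group or a methylsulfonyl group. It also leaves open whether the ureido group would give a similar step on a longer chain.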